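The source may report more compounds than this note shows. Statements on the series, on what has been measured and on what is new or still open speak of the compounds shown alone.

Two compounds of the series carry numbers in a functional assay on A549 cells (Homo sapiens) for cytotoxicity, read by MTT assay, with a stated time of 24 h; a higher number here means a weaker inhibitor, a lower number a stronger inhibitor. Compound 1 `COc1ccc(/C=C\C(=O)O)c(OCc2cn(-c3ccccc3)nn2)c1CC=C(C)C` gives 40500 nM in this assay. Compound 2 `COc1ccc(/C=C\C(=O)O)c(OCc2cn(-c3cccnc3Cl)nn2)c1CC=C(C)C` gives 5600 nM in this assay. Going by the values given here, the single measured step, a 7.2-fold lower number from compound 1 to compound 2 (0.86 log units; beyond the scatter), is the only comparison in hand. Compound 2 therefore holds the lowest of the two numbers, with compound 1 the nearest at a higher number, a gap beyond the scatter.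

Compound 3 `COc1ccc(/C=C\C(=O)O)c(OCc2cn(-c3nc4ccccc4s3)nn2)c1CC=C(C)C` is still to be measured. It differs from compound 2 in one place: 1,3-benzothiazol-2-yl in place of 2-chloropyridin-3-yl on an aromatic nitrogen. The step from compound 1 to compound 2 bears on this change, as it also exchanged the group on that aromatic nitrogen, and it was modest yet beyond the scatter. Among the compounds with values here, no measured step shows a fused bicyclic group in that place, so the direction for compound 3 in this assay is open, and a step no larger than the one already seen is the working assumption. Compound 3 is expected near 6000 nM in this assay, within 1500 nM to 25000 nM. That estimate means an expected step of a 1.1-fold higher number from compound 2 to compound 3 (0.03 log units; within the scatter).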

Compound 3, half-maximal inhibitory concentration: 42100 nM
Estimate against measurement, compound 3: 7.0-fold (0.85 log units) below; the whole stated range lies below it.
By their numbers in this assay, from the lowest: compound 2; then compounds 1 and 3 (each within the scatter of the next).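

In this assay the exchange of 2-chloropyridin-3-yl for 1,3-benzothiazol-2-yl on the aromatic nitrogen gives a 7.5-fold higher number from compound 2 to compound 3 (0.88 log units; beyond the scatter), so the position does not simply accept any replacement for phenyl with the same result as 2-chloropyridin-3-yl. Set against phenyl, the same group gives a 1.0-fold higher number from compound 1 to compound 3 (0.02 log units; within the scatter), which leaves phenyl and 1,3-benzothiazol-2-yl indistinguishable here and makes 2-chloropyridin-3-yl the only one of the three groups that stands apart, despite the extra ring and the larger heavy-atom count of 1,3-benzothiazol-2-yl. Nothing beyond these cytotoxicity numbers is available to account for that separation.

The compounds shown leave the chlorine and the ring nitrogen of 2-chloropyridin-3-yl unseparated, as the two enter together in that one group. Going by these compounds, a plain pyridin-3-yl or a 2-chlorophenyl group on the same aromatic nitrogen would test each alone, and whether the number in this assay holds with an amine on that ring remains open as well.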